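The source may hold more compounds than are shown below. What is called first, only, known or untested is meant among the compounds shown, and "the series" means these compounds.

Measured compounds:
Compound 1 `CC(=O)NCCN(C)c1cccc(OCCCCNC(=O)Oc2cccc(-c3ccccc3)c2)c1`: in an assay on cells for displacement of a labelled ligand from melatonin receptor type 1A (Homo sapiens), using the Cheng-Prusoff equation, with a stated time of 90 min (a higher number here means a weaker inhibitor, a lower number a stronger inhibitor), compound 1 gives 12.9 nM.
Compound 2 `CC(=O)NCCN(C)c1cccc(OCCCCCCNC(=O)Oc2cccc(-c3ccccc3)c2)c1`: in this assay compound 2 gives 21.4 nM.

Compound 2 has the higher of the two numbers, but its value and that of compound 1 lie within the scatter of each other, so the two cannot be told apart on this evidence.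

Compound 3 `CC(=O)NCCN(C)c1cccc(OCCCCCCNC(=O)Oc2cccc(-c3cccc(O)c3)c2)c1` is not yet measured. It differs from compound 2 by hydroxy in place of hydrogen on an aromatic carbon. Among the measured compounds shown here, no measured pair shows what this change does here, so the expectation rests on compound 2 alone.

The step is expected to be small, either no change beyond the scatter or a modest rise in number, giving an estimated 1.4-fold higher number from compound 2 to compound 3 (0.15 log units; within the scatter). Compound 3 is therefore expected to give about 30 nM in this assay, with a range from 8 nM to 120 nM.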

Compound 3, inhibition constant: 29.5 nM
Compound 3: middle estimate off by 1.0-fold (0.01 log units), on the high side; measured number inside the range.
By their numbers in this assay, from the lowest: compounds 1, 2 and 3 (each within the scatter of the next, the first and the last beyond it).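

In this assay, among the compounds shown here, the replacement of phenyl by 3-hydroxyphenyl gives a 1.4-fold higher number from compound 2 to compound 3 (0.14 log units; within the scatter) and so offers the first measured look at this replacement, which compounds 1 and 2 could not provide. At this position, meta to a large group, adding a hydroxy with its hydrogen-bond donor and acceptor leaves a number that cannot be told apart from that of compound 2. Nothing measured here explains this result.

This single pair leaves open whether hydroxy would give a similar result at other carbons of that ring or on compound 1, which has the shorter chain. It also leaves open what an amine, a carboxylic acid or a methoxy group would do at this same position.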